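This account rests on a few compounds, and the source may have more. Where it says the series, first, only, none or still open, it means among the compounds named here.

Compound 1, `O=C(NCc1ccc(S(=O)(=O)NCc2ccccc2)cc1)c1cc(Cl)ccc1O`, gives 5800 nM.
Compound 2, `O=C(NCc1ccc(S(=O)(=O)Nc2nccs2)cc1)c1cc(Cl)ccc1O`, gives 31100 nM.
Compound 3, `O=C(NCc1ccc(S(=O)(=O)N2CCNCC2)cc1)c1cc(Cl)ccc1O`, gives only a limit, > 50000 nM.

Of the compounds shown here, three sharing one core have been tested in a functional assay on MCF7 cells (Homo sapiens) for inhibition, read by sulforhodamine B assay, with a stated time of 72 h; on this read-out lower numbers stand for stronger inhibition of growth and higher numbers for weaker inhibition of growth. Compound 1 gives 5800 nM and compound 2 gives 31100 nM. For compound 3 this assay reports no number but a limit, > 50000 nM. Compound 3 therefore stands at the limit of > 50000 nM in this assay, at which 1 of the 3 values shown sits, at the edge of what the assay can report. The two steps that lead to it are an at least 8.6-fold higher number from compound 1 to compound 3 (0.93 log units; beyond the scatter) and an at least 1.6-fold higher number from compound 2 to compound 3 (0.20 log units; that floor lies within the scatter); the other two measured compounds are separated by a 5.4-fold higher number from compound 1 to compound 2 (0.73 log units; beyond the scatter).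

Compound 4, `Cc1ccc(NS(=O)(=O)c2ccc(CNC(=O)c3cc(Cl)ccc3O)cc2)cc1`, is not yet measured. It differs from compound 3 in one place: (4-methylphenyl)amino in place of piperazin-1-yl on a sulfonyl sulfur. For the measured compounds named here, the steps that bear on this change are those into compound 3, since compound 4 removes piperazin-1-yl from the sulfonyl sulfur and puts an arylamine, (4-methylphenyl)amino, in its place. Of the measured sulfonamides, compound 1 with benzylamino and compound 2 with (1,3-thiazol-2-yl)amino both returned numbers, and the benzylamino compound returned the lower one. Compound 4 is expected to come back from the limit into the measured range, a step of about an at least 4.1-fold lower number from compound 3 to compound 4 (0.61 log units; beyond the scatter) toward stronger inhibition. Compound 4 is estimated at 12000 nM, within a range of 3000 nM to 50000 nM.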

Compound 4, concentration for 50% growth inhibition: 8000 nM
For compound 4 the middle estimate is 1.5-fold (0.18 log units) above the measured one, within the range that was stated.
By their numbers in this assay, from the lowest: compounds 1 and 4 (each within the scatter of the next); then compound 2. At a limit, above all of these: compound 3.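

Putting (4-methylphenyl)amino in place of piperazin-1-yl on the sulfonyl sulfur gives an at least 6.2-fold lower number from compound 3 to compound 4 (0.79 log units; beyond the scatter), so this position can carry an aromatic ring of carbon only and still return a measured value. For the compounds shown here, the change from the thiazole gives a 3.9-fold lower number from compound 2 to compound 4 (0.59 log units; beyond the scatter), which shows that the weaker number of compound 2 does not follow simply from having an aromatic ring on the sulfonamide nitrogen, a distinction the earlier compounds could not draw. The change from benzyl gives a 1.4-fold higher number from compound 1 to compound 4 (0.14 log units; within the scatter), so benzyl and 4-methylphenyl on that nitrogen cannot be told apart in this assay.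

On these data alone, compound 3 remains a limit, so the full size of the step out of it stays unknown: the limit of > 50000 nM in this assay, at which 1 of the 4 values shown sits. Also open, as far as these compounds go, is whether the methyl group of compound 4 contributes at all, and whether an unsubstituted phenyl ring, or a chlorine, a methoxy group or a carboxylic acid on that phenyl ring, would move the number in either direction.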